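The source may report more compounds than this note shows. Statements on the series, on what has been measured and on what is new or still open speak of the compounds shown alone.

Of the compounds shown here, three with a shared core have been measured in a physicochemical assay for solubility, read by LC-MS, in phosphate buffer, with a stated time of 24 h, at pH 7.4 (on this read-out higher numbers stand for higher solubility and lower numbers for lower solubility), and none of them gives a number. Compound 1 (`O=C(Nc1ccccc1)c1cnc(NCc2c(F)ccc3c2CCO3)n2cnnc12`) reads < 1000 nM in this assay, which is a limit of the assay and not a number. Compound 2 (`Cc1ncccc1-c1cnc(NCc2c(F)ccc3c2CCO3)c2n[nH]c(=O)n12`) reads < 2000 nM, also a limit. Compound 3 (`O=C1CCCN1c1cnc(NCc2c(F)ccc3c2CCO3)c2cn[nH]c(=O)c12`) reads < 2000 nM, again a limit, so its standing is known only as a range.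

Compound 4 (`CNC(=O)c1cc(-c2cnc(NCc3c(F)ccc4c3CCO4)c3cn[nH]c(=O)c23)n(C)n1`) departs from compound 3 in one place: 1-methyl-3-(methylcarbamoyl)-1H-pyrazol-5-yl in place of 2-oxopyrrolidin-1-yl on an aromatic carbon. A 1-methyl-3-(methylcarbamoyl)-1H-pyrazol-5-yl group enters in place of 2-oxopyrrolidin-1-yl, on an aromatic carbon of a six-membered aromatic ring with 1 nitrogen, part of a fused or bridged system of two rings. Within the data shown here, no measured pair of compounds differs in a single place, so no measured step can serve as a guide.

The expectation therefore rests on compound 3 and its limit of < 2000 nM. The expected change is a step that the limit leaves unreadable from compound 3 to compound 4, an estimate that stays within the scatter and has no clear direction. For compound 4 the estimated value is 1500 nM, with an expected range from 300 nM to 6000 nM.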

Compound 4, solubility: 7000 nM
Compound 4: middle estimate off by 4.7-fold (0.67 log units), on the low side; measured number outside the range, above it.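

In this assay, among these compounds, compound 4 is the first compound here to give a number, and the swap of 2-oxopyrrolidin-1-yl for 1-methyl-3-(methylcarbamoyl)-1H-pyrazol-5-yl gives the first readable step at this place, on an aromatic carbon of a six-membered aromatic ring with 1 nitrogen: an at least 3.5-fold higher number from compound 3 to compound 4 (0.54 log units; beyond the scatter). From the compounds shown here alone, compound 3 reads < 2000 nM, which is a limit and not a number, so the step gives only a minimum and its full size stays unknown: the limit of < 2000 nM in this assay, at which 2 of the 4 values shown sit. The change therefore shows that this place can carry a larger group, with 10 heavy atoms in place of 6 and 1 hydrogen-bond donor in place of 0, while the read-out rises beyond the scatter.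

Compounds 3 and 4 differ in the whole group, so they leave open which part of the entering group goes with the higher number: the five-membered aromatic ring, its methyl, or its methylcarbamoyl. Also open, going by these compounds, is how a carboxylic acid, a primary amine or a morpholine on the same aromatic carbon would read, and whether the same swap would give a similar step on the cores of compound 1 and compound 2.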